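A few compounds are considered here, and "the series" means these few. Any claim that something is new, unique, unknown or untested is made for them only; others in the source may bear on it.

Of the compounds shown here, two sharing one core have been measured so far. Compound 1 `Cc1ccc(S(=O)(=O)N(C)c2ccc3[nH]c(-c4n[nH]c5ccccc45)cc3n2)cc1` gives, in a functional assay on HL-60 cells (Homo sapiens) for antiproliferative activity, read by MTT assay, with a stated time of 72 h (on this read-out higher numbers stand for weaker inhibition and lower numbers for stronger inhibition), a value of 3030 nM. Compound 2 `COc1ccc(S(=O)(=O)N(C)c2ccc3[nH]c(-c4n[nH]c5ccccc45)cc3n2)c(OC)c1` gives 5180 nM in this assay. Among the compounds with values here, compound 2 thus holds the higher of the two numbers, but the single step of a 1.7-fold higher number from compound 1 to compound 2 (0.23 log units; within the scatter) is within the scatter, so the two compounds cannot be told apart on this read-out.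

Compound 3 `CN(c1ccc2[nH]c(-c3n[nH]c4ccccc34)cc2n1)S(=O)(=O)c1cccc([N+](=O)[O-])c1` is the next compound. Its change from compound 2 is 3-nitrophenyl in place of 2,4-dimethoxyphenyl on a sulfonyl sulfur. Within the data shown here, the only measured step that bears on it is the one from compound 1 to compound 2, which also swapped the aryl group on the sulfonyl sulfur and stayed within the scatter. A further swap at the same place is therefore expected to move the number by no more than the scatter, in no set direction, as given by a 1.3-fold lower number from compound 2 to compound 3 (0.11 log units; within the scatter). Compound 3 is accordingly expected to give about 4000 nM in this assay, with a range from 1500 nM to 12000 nM.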

Compound 3, half-maximal inhibitory concentration: 3660 nM
The estimate for compound 3 lay 1.1-fold (0.04 log units) above the measured number, and the stated range covers the measured number.
By their numbers in this assay, from the lowest: compounds 1, 3 and 2 (each within the scatter of the next).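

Three different aryl groups have now been compared on the sulfonyl sulfur, and in this assay the 3-nitrophenyl group gives a 1.4-fold lower number from compound 2 to compound 3 (0.15 log units; within the scatter) as well as a 1.2-fold higher number from compound 1 to compound 3 (0.08 log units; within the scatter) in the second comparison. Together with the earlier step, this means that 4-methylphenyl, 2,4-dimethoxyphenyl and 3-nitrophenyl cannot be told apart on this read-out, even though only 3-nitrophenyl carries nitrogen. Among these three compounds, exchanging one substituted phenyl group for another at this place leaves no difference that can be read, and nothing on hand speaks to why that is.

Still open, going by these compounds, is whether an amine or a carboxylic acid on the phenyl ring, or a longer chain in place of that ring, would give a number beyond the scatter. All three compounds also share one core, so they say nothing about changes anywhere else in the structure.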